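The source may hold more compounds than are shown below. What is called first, only, known or untested is meant among the compounds shown, and "the series" means these compounds.

Of the compounds shown here, three sharing one core have been tested in an in vitro functional assay on cells for agonist activity at Bombesin receptor subtype-3 (Mus musculus), read by luminescence and calcium flux; on this read-out lower numbers stand for an effect already at smaller amounts and higher numbers for an effect only at larger amounts of compound. Compound 1 `O=C(O)c1ccccc1-c1ccc(CCc2ncc(CC3CCC3)[nH]2)cc1` gives 7.1 nM. Compound 2 `N#Cc1ccccc1Cc1cnc(CCc2ccc(-c3ccccc3C(=O)O)cc2)[nH]1` gives 642 nM. Compound 3 `O=C(O)c1ccccc1-c1ccc(CCc2ncc(C3CCCCC3)[nH]2)cc1` gives 14.7 nM, which places it second highest of the three numbers, close to compound 1 and far from compound 2. The steps among them are a 90-fold higher number from compound 1 to compound 2 (1.96 log units; beyond the scatter), a 2.1-fold higher number from compound 1 to compound 3 (0.32 log units; beyond the scatter) and a 44-fold lower number from compound 2 to compound 3 (1.64 log units; beyond the scatter).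

Compound 4 `CCC(C)(CC)Cc1cnc(CCc2ccc(-c3ccccc3C(=O)O)cc2)[nH]1` has not yet been measured. Its difference from compound 3 is 2-ethyl-2-methylbutyl in place of cyclohexyl on an aromatic carbon. Among the compounds with values here, two measured steps bear on this change. The step of a 2.1-fold higher number from compound 1 to compound 3 (0.32 log units; beyond the scatter) shows that exchanging one group built only of carbon for another of similar size on this aromatic carbon moved the number only modestly. The step of a 44-fold lower number from compound 2 to compound 3 (1.64 log units; beyond the scatter) shows the large shift seen when a group bearing a nitrile on an aromatic ring sits there instead; compound 4 carries no such group, only carbon and no ring. A small step is therefore expected in this assay for compound 4, in either direction. The estimate for compound 4 is 9 nM with a range of 3 nM to 30 nM. This corresponds to an expected step of a 1.6-fold lower number from compound 3 to compound 4 (0.21 log units; within the scatter).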

Compound 4, half-maximal effective concentration: 30 nM
Beside the measured number, compound 4's estimate is 3.3-fold (0.52 log units) below it; the range from low to high includes it.
By their numbers in this assay, from the lowest: compound 1; then compound 3; then compound 4; then compound 2.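

The ring at this position is not essential: the open-chain 2-ethyl-2-methylbutyl group, with no ring at all, costs only a modest step when it replaces cyclohexyl (a 2.0-fold higher number from compound 3 to compound 4 (0.31 log units; beyond the scatter)), although that step lies beyond the scatter. On the saturated chain carbon that carries cyclobutyl in compound 1, 1-ethyl-1-methylpropyl also gives only a modest change (a 4.2-fold higher number from compound 1 to compound 4 (0.63 log units; beyond the scatter)), while the same group stands far from the 2-cyanophenyl of compound 2 (a 21-fold lower number from compound 2 to compound 4 (1.33 log units; beyond the scatter)). Among these four compounds, the three groups built only of carbon therefore stay within modest steps of one another, with or without a ring, and compound 2, whose group also holds a nitrile and an aromatic ring, is the one that goes against them.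

These compounds leave open whether the large step of compound 2 goes with its nitrile or its aromatic ring, which a plain benzyl group at this position would begin to separate, and how an amine on the chain would read. Nothing measured here explains why the open chain gives a higher number than the cyclohexyl ring.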